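The source may hold more compounds than are shown below. What is called first, only, known or untested is meant among the compounds shown, and "the series" means these compounds.

Measured in a functional assay on MCF7 cells (Homo sapiens) for inhibition; on this read-out lower numbers stand for stronger inhibition and higher numbers for weaker inhibition:
- compound 1 `CCN(CC)CCNC(=O)CC(CC(=O)NC1Cc2ccccc2C1)c1ccc(Cl)cc1`: 75000 nM
- compound 2 `CN(C(=O)CC(CC(=O)NCCN1CCCC1)c1ccc(Cl)cc1)C1Cc2ccccc2C1`: 76700 nM
- compound 3 `CCN(CC)CCNC(=O)CC(CC(=O)N(C)C1Cc2ccccc2C1)c1ccccc1`: > 100000 nM

Compound 3 has no numeric value on this read-out. Its entry of > 100000 nM is a limit of this assay.

The next compound to be measured is compound 4 `CCN(CC)CCNC(=O)CC(CC(=O)N(C)C1Cc2ccccc2C1)c1ccc(Cl)cc1`, where chloro replaces hydrogen on an aromatic carbon, turning phenyl into 4-chlorophenyl: chloro in place of hydrogen on an aromatic carbon. The change sits on a six-membered aromatic ring of carbon only, para to a large group.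

For the measured compounds named here, no step between measured compounds isolates this change, so the expectation rests on indirect evidence. Compound 1 at 75000 nM and compound 2 at 76700 nM both carry the 4-chlorophenyl group, and these two values lie within the scatter of each other. A modest at least 1.4-fold lower number from compound 3 to compound 4 (0.15 log units; that floor lies within the scatter) toward stronger inhibition is therefore expected, though the true size remains uncertain while one end is only a limit. For compound 4 the estimated value is 70000 nM, with an expected range of 35000 nM to 100000 nM.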

Compound 4, half-maximal inhibitory concentration: 28800 nM
Compound 4: middle estimate off by 2.4-fold (0.39 log units), on the high side; measured number outside the range, below it.
By their numbers in this assay, from the lowest: compound 4; then compounds 1 and 2 (each within the scatter of the next). At a limit, above all of these: compound 3.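

In this assay, the first direct read of chloro on this aromatic carbon gives an at least 3.4-fold lower number from compound 3 to compound 4 (0.54 log units; beyond the scatter), so the change to 4-chlorophenyl moves the number toward stronger inhibition by more than the scatter. The entry for compound 3 is a limit, so this step has only a floor and its true size stays open: the limit of > 100000 nM in this assay, at which 1 of the 4 values shown sits.
With the 4-chlorophenyl group in place, the two other single changes also count: methyl in place of hydrogen on the amide-type nitrogen gives a 2.6-fold lower number from compound 1 to compound 4 (0.42 log units; beyond the scatter), and diethylamino in place of pyrrolidin-1-yl gives a 2.7-fold lower number from compound 2 to compound 4 (0.43 log units; beyond the scatter).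

Still open, as far as these compounds go, is how fluoro, methoxy or trifluoromethyl on the same aromatic carbon would compare with chloro. Also open, from the compounds shown here alone, is whether the chloro step carries over to the core of compound 1 or compound 2.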